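This account rests on a few compounds, and the source may have more. Where it says the series, first, only, none or still open, it means among the compounds named here.

In a functional assay on HEL cells (Homo sapiens), read by microscopy (a higher number here means that more compound is tolerated, a lower number that less compound is tolerated), compound 1 `CCCCCCCc1cc2cn(COCCO)c(O)nc-2n1` gives only a limit, >= 400000 nM. That limit is as far as the test reaches, so no number is known for compound 1. Compound 2 `CCCCC#Cc1cc2cn(COCCO)c(=O)nc2o1` likewise stops at a limit, > 100000 nM. Compound 3 `CC(C)[C@@H](NC(N)=O)C(=O)O` also stops at a limit, > 400000 nM. Among the measured compounds shown here, none of the three shows toxicity within the tested range, so there is no measured step to lean on. Compound 4 `CCCCCCc1cc2cn(COCCO)c(O)nc-2n1` differs from compound 1 by hydrogen in place of methyl on a saturated chain carbon, six bonds along the chain from an aromatic carbon. Compound 1 stands at a limit, >= 400000 nM. The step expected here, a number no higher from compound 1 to compound 4 (the limit leaves the size open), is none beyond the scatter. Compound 4 is therefore estimated at 400000 nM, with a range from 200000 nM to 800000 nM, most likely reported again only as a limit.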

Compound 4, minimum cytotoxic concentration: > 400000 nM
Compound 4: no number, only a limit (the forecaster's own chance of this, stated with the estimate: 85%); the middle value sits exactly at the limit.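

Compound 1 and compound 4 both stop at a limit, so the step between them cannot be read. The compounds shown leave open at what concentration any of them would begin to harm the cells.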